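Working notes: from compound 3 to compound 4

The compounds below may be only part of what the source reports. "The series", "measured", "known", "first", "only" and "open" are said of these compounds alone.

Compound 1 `CCc1nc2ccccc2n1CCCOc1ccccc1` gives > 50 uM in an ADME assay on Vero cells (Chlorocebus sabaeus) for cytotoxicity, read by luminescence, with a stated time of 2 days (a higher number here means that more compound is tolerated, a lower number that less compound is tolerated), as a limit of the assay, not a number.

Going by the values given here, compound 2 `CCc1nc2ccccc2n1CCCCOc1ccccc1` gives 21 uM and compound 3 `CCc1nc2ccccc2n1CCCCOc1ccc(C)cc1` gives 14 uM in this assay as the only two numbers so far. These two values lie within the scatter of each other, so compound 3 stands level with compound 2. Methyl in place of hydrogen on an aromatic carbon links them, and it amounts to a 1.5-fold lower number from compound 2 to compound 3 (0.18 log units; within the scatter) as the only measured step in the series.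

Among the compounds with values here, compound 4 `CCc1nc2ccccc2n1CCCCOCc1ccccc1` differs from compound 3 by benzyl in place of 4-methylphenyl on an oxygen on a saturated carbon as its one change: benzyl in place of 4-methylphenyl on an oxygen on a saturated carbon. The two have the same atoms, joined differently. Within the data shown here, no measured step covers this exchange directly. The closest guide is the methyl change that leads to compound 3, which gave a 1.5-fold lower number from compound 2 to compound 3 (0.18 log units; within the scatter) and so offers no sign of a large effect from that end of the molecule. No step beyond the scatter is therefore expected, and no direction is favoured.

The expected change is a 1.1-fold higher number from compound 3 to compound 4 (0.06 log units; within the scatter) and should stay within the scatter.

Compound 4 is estimated at 16 uM in this assay with an expected range from 7 uM to 35 uM as its likely span.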

Compound 4, half-maximal toxic concentration: 32 uM
For compound 4 the middle estimate is 2.0-fold (0.30 log units) below the measured one; measured number inside the range.
By their numbers in this assay, from the lowest: compounds 3, 2 and 4 (each within the scatter of the next, the first and the last beyond it). At a limit, above all of these: compound 1.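

In this assay, going by these compounds alone, benzyl in place of 4-methylphenyl on an oxygen on a saturated carbon gives a 2.3-fold higher number from compound 3 to compound 4 (0.36 log units; beyond the scatter) as the first step beyond the scatter, though only a modest one. Benzyl in place of phenyl at the same place gives a 1.5-fold higher number from compound 2 to compound 4 (0.18 log units; within the scatter) and stays within the scatter, so the change reads differently depending on the group it replaces. The groups that leave and enter in the first of these steps match in every count, with the same heavy atoms and one six-membered aromatic ring of carbon only, and they differ only in how those atoms are joined, which the methyl step alone could not show.

Compound 1 gives > 50 uM as a limit of the assay and not a number, so the steps that involve it cannot be read: the limit of > 50 uM in this assay, at which 1 of the 4 values shown sits. Going by these compounds, whether a longer chain, an amine or a carboxylic acid in place of benzyl would take the number in this assay beyond the scatter of compound 4 remains open.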